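Heteroaryl swaps on a diphenylmethyl sulfoxide dopamine transporter series

The source may hold more compounds than are shown below. What is called first, only, known or untested is meant among the compounds shown, and "the series" means these compounds.

Measured compounds:
compound 1, `COC1NN=C(C[S+]([O-])C(c2ccccc2)c2ccccc2)S1`, 108000 nM
compound 2, `Cc1scc(C[S+]([O-])C(c2ccccc2)c2ccccc2)c1C`, 284000 nM

Of the compounds shown here, two have been measured in an assay on HEK293 cells for inhibition of sodium-dependent dopamine transporter (Homo sapiens), read by scintillation counting, with stated times of 5 min and 1 min; a lower number here means a stronger inhibitor, a higher number a weaker inhibitor. Compound 1 `COC1NN=C(C[S+]([O-])C(c2ccccc2)c2ccccc2)S1` gives 108000 nM, the lowest of the two numbers; its nearest neighbour is compound 2 `Cc1scc(C[S+]([O-])C(c2ccccc2)c2ccccc2)c1C`, which gives 284000 nM. Among the compounds with values here, the one measured step, a 2.6-fold higher number from compound 1 to compound 2 (0.42 log units; beyond the scatter), exchanges the ring on the saturated chain carbon bound to a sulfur for a five-membered aromatic ring with one hetero atom, and it is modest.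

Compound 3 `Cc1cc(O)nc(C[S+]([O-])C(c2ccccc2)c2ccccc2)n1` is not yet measured. It differs from compound 1 in the same place: a group of 8 heavy atoms (5 carbon, 2 nitrogen, 1 oxygen; one six-membered aromatic ring with 2 hetero atoms) in place of a group of 7 heavy atoms (3 carbon, 2 nitrogen, 1 oxygen, 1 sulfur; one five-membered non-aromatic ring with 3 hetero atoms), on a saturated chain carbon bound to a sulfur

The step from compound 1 to compound 2 is the only one that bears on this change, and it was modest in this assay. Both compounds sit far from strong inhibition, and the entering 4-hydroxy-6-methylpyrimidin-2-yl ring is again a heteroaryl replacement at the same carbon, so a comparably small shift is expected rather than a large one. The step of a 1.4-fold higher number from compound 1 to compound 3 (0.14 log units; within the scatter) is therefore expected to stay near the scatter or slightly beyond it, in the weaker direction. Compound 3 is estimated at 150000 nM, with a range from 50000 nM to 450000 nM.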

Compound 3, half-maximal inhibitory concentration: 109000 nM
Compound 3: the middle estimate sits 1.4-fold (0.14 log units) above what was measured, and the stated range covers the measured number.
By their numbers in this assay, from the lowest: compounds 1 and 3 (each within the scatter of the next); then compound 2.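

In this assay, replacing the five-membered non-aromatic ring on the saturated chain carbon bound to a sulfur with 4-hydroxy-6-methylpyrimidin-2-yl gives a 1.0-fold higher number from compound 1 to compound 3 (0.00 log units; within the scatter), so at this place the two rings cannot be told apart, despite differing in ring size and aromatic character. Within the data shown here, replacing 4,5-dimethylthiophen-3-yl with the same 4-hydroxy-6-methylpyrimidin-2-yl gives a 2.6-fold lower number from compound 2 to compound 3 (0.42 log units; beyond the scatter), which mirrors the earlier step from the other side and leaves the thiophene-bearing compound as the one that stands apart among the three, carrying the only group here without nitrogen. No evidence at hand bears on why the numbers fall this way.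

The compounds shown leave open whether an amine or a carboxylic acid on this carbon, or a longer chain between the sulfur and the ring, would move the number well away from this range. They also do not separate the hydroxy group from the methyl group of compound 3, as the two occur only together on its pyrimidine ring.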